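Replacing the trifluoromethyl group of compound 3

This account rests on a few compounds, and the source may have more. Where it says the series, first, only, none or still open, it means among the compounds named here.

Values in a functional assay on NCI-H460 cells (Homo sapiens) for cytotoxicity, read by MTT assay, with a stated time of 68 h; on this read-out higher numbers stand for weaker inhibition and lower numbers for stronger inhibition:
Compound 1 `O=C(Nc1cccc(-c2ccccc2C(F)(F)F)c1)C(Cl)Cl`: 7550 nM
Compound 2 `O=C(Nc1cccc(-c2cccc(F)c2)c1)C(Cl)Cl`: > 50000 nM, a limit of the assay
Compound 3 `O=C(Nc1cccc(-c2cccc(C(F)(F)F)c2)c1)C(Cl)Cl`: 30200 nM

Only two of these results are true numbers. Compound 3 holds the higher of them at 30200 nM, while compound 1 lies lower at 7550 nM, a gap beyond the scatter. The result for compound 2 is a limit and not a number.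

The next structure is compound 4 `O=C(Nc1cccc(-c2cccc(NC(=O)C(Cl)Cl)c2)c1)C(Cl)Cl`. The difference is ((dichloromethyl)carbonyl)amino in place of trifluoromethyl on an aromatic carbon, with ((dichloromethyl)carbonyl)amino in place of trifluoromethyl on an aromatic carbon.

For the measured compounds named here, one measured step touches this position: an at least 1.6-fold lower number from compound 2 to compound 3 (0.21 log units; that floor lies within the scatter). It brings in trifluoromethyl in place of fluoro, and its floor lies within the scatter. Going by the values given here, it therefore gives only weak guidance, and no measured step involves the entering group. With no evidence for a shift in either direction, no change beyond the scatter is expected in this assay.

The estimated step is a 1.4-fold lower number from compound 3 to compound 4 (0.14 log units; within the scatter). Compound 4 is estimated at 22000 nM, with an expected range from 6000 nM to 50000 nM.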

Compound 4, half-maximal inhibitory concentration: > 50000 nM
Compound 4: a limit, no number; the forecaster's own chance of this, stated with the estimate: 20%; at least 2.2-fold (0.35 log units) between middle value and limit.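

In this assay compound 4 gives > 50000 nM, a limit and not a number. Going by these compounds, the entering ((dichloromethyl)carbonyl)amino, which unlike trifluoromethyl carries a hydrogen-bond donor and a hydrogen-bond acceptor, gives an at least 1.6-fold higher number from compound 3 to compound 4 (0.21 log units; that floor lies within the scatter), so this change at this position did not bring the result under the limit, although the true size of the step stays unknown and its floor does not establish a loss of activity. The step between compound 2 and compound 4 cannot be read, as both results rest on the same limit, so the two groups cannot be ranked against each other: the limit of > 50000 nM in this assay, at which 2 of the 4 values shown sit.

The compounds shown leave open whether a smaller group at this position, such as an amine or a carboxylic acid, would give a true number in this assay. They also leave open whether ((dichloromethyl)carbonyl)amino would fare differently at the place where compound 1, at 7550 nM, holds its trifluoromethyl.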